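Shortening one ester chain on the shared core

The source may hold more compounds than are shown below. What is called first, only, known or untested is meant among the compounds shown, and "the series" means these compounds.

Compound 1, `CCOC(=O)C1=C(C)NC(C)=C(C(=O)OC)C1c1[nH]c(CC)nc1Cl`, gives 2.02 nM in an assay on ileum for inhibition of Voltage-dependent L-type calcium channel subunit alpha-1C (Cavia porcellus); a higher number here means a weaker inhibitor, a lower number a stronger inhibitor.
Compound 2, `CCOC(=O)C1=C(C)NC(C)=C(C(=O)OCC)C1c1[nH]c(CC)nc1Cl`, gives 0.158 nM in this assay.
Compound 3, `CCCOC(=O)C1=C(C)NC(C)=C(C(=O)OCCC)C1c1[nH]c(CC)nc1Cl`, gives 0.13 nM in this assay.

Compound 3 has the lowest of the three numbers, but its gap to compound 2 is within the scatter, so the two cannot be told apart; only compound 1 stands clearly apart, with a higher number beyond the scatter.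

Compound 4, `CCCOC(=O)C1=C(C)NC(C)=C(C(=O)OCC)C1c1[nH]c(CC)nc1Cl`, is not yet measured. It differs from compound 3 by hydrogen in place of methyl on a saturated chain carbon, two bonds along the chain from an oxygen next to a carbonyl group, so one of the two ester chains is shortened from propyl to ethyl while the other stays propyl.

Going by the values given here, the only measured step that touches an ester chain is a 13-fold lower number from compound 1 to compound 2 (1.11 log units; beyond the scatter), which lengthened the chain right at the oxygen. The change here sits one carbon further out, and compound 2 and compound 3, which differ by that same outer carbon on both chains at once, show numbers within the scatter of each other. A step of no size beyond the scatter is therefore expected in this assay.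

Compound 4 is estimated to give 0.15 nM, in the range 0.07 nM to 0.32 nM; the expected step is a 1.2-fold higher number from compound 3 to compound 4 (0.06 log units; within the scatter).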

Compound 4, half-maximal inhibitory concentration: 0.543 nM
Compound 4: the middle estimate sits 3.6-fold (0.56 log units) below what was measured; measured number above the stated range.
By their numbers in this assay, from the lowest: compounds 3 and 2 (each within the scatter of the next); then compound 4; then compound 1.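

The methyl at this place on a single ester chain is not silent in this assay: there is a 4.2-fold higher number from compound 3 to compound 4 (0.62 log units; beyond the scatter), and from the other side there is a 3.4-fold higher number from compound 2 to compound 4 (0.54 log units; beyond the scatter), even though compound 2 and compound 3 lie within the scatter of each other. Extending the shorter chain of compound 1 from methyl to propyl still helps, with a 3.7-fold lower number from compound 1 to compound 4 (0.57 log units; beyond the scatter), so the mixed propyl and ethyl pair keeps part of the gain but does not match the two compounds with equal chains. Adding the same methyl to an ester chain therefore does not give a fixed step, and its size depends on the chains already present on the shared core: the same change on two cores in this assay, a 13-fold lower number (1.11 log units; beyond the scatter) from compound 1 to compound 2 and a 4.2-fold lower number (0.62 log units; beyond the scatter) from compound 4 to compound 3, 3.1-fold (0.49 log units) apart, beyond the scatter of two such steps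

The compounds shown do not tell whether a longer chain such as butyl, a branched chain such as isopropyl, or a chain ending in an amine would hold these low numbers. They also leave open whether the pattern would survive replacing the chlorine or the ethyl group on the ring that carries them.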